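From 2-chlorophenyl to 3-chlorophenyl: notes on compound 4

The source may hold more compounds than are shown below. What is called first, only, known or untested is meant among the compounds shown, and "the series" means these compounds.

In a functional assay on HL-60 cells (Homo sapiens) for antiproliferative activity, read by MTT assay, with a stated time of 72 h (on this read-out lower numbers stand for stronger inhibition and higher numbers for weaker inhibition), compound 1 `NC1=NC2(CCSCC2)N(OCCCOc2cccc(Cl)c2)C(N)=N1` gives 260 nM, compound 2 `NC1=NC2(CCSCC2)N(OCCCOc2ccc(Br)cc2)C(N)=N1` gives 350 nM and compound 3 `NC1=NC2(CCOCC2)N(OCCCOc2ccccc2Cl)C(N)=N1` gives 660 nM. Compound 3 sits within the scatter of compound 2 and beyond the scatter of compound 1, whose number is lower.

Compound 4 `NC1=NC2(CCOCC2)N(OCCCOc2cccc(Cl)c2)C(N)=N1` keeps the core of compound 3 and changes one group: 3-chlorophenyl in place of 2-chlorophenyl on an oxygen on a saturated carbon. One measured step changes the group at that place, a 1.3-fold higher number from compound 1 to compound 2 (0.13 log units; within the scatter), and it stays within the scatter, although on a different core. Compound 1 at 260 nM carries the same 3-chlorophenyl on that other core. Among the measured compounds shown here, no measured step changes the core alone, so this is weak support for a lower number.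

The expected change is small, toward a lower number and probably not beyond the scatter: a 1.5-fold lower number from compound 3 to compound 4 (0.17 log units; within the scatter) in this assay. For compound 4 the estimated value is 450 nM, with an expected range of 200 nM to 1000 nM.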

Compound 4, half-maximal inhibitory concentration: 520 nM
The estimate for compound 4 lay 1.2-fold (0.06 log units) below the measured number, within the range that was stated.
By their numbers in this assay, from the lowest: compounds 1, 2, 4 and 3 (each within the scatter of the next, the first and the last beyond it).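

In this assay, among the compounds shown here, 3-chlorophenyl in place of 2-chlorophenyl on an oxygen on a saturated carbon gives a 1.3-fold lower number from compound 3 to compound 4 (0.10 log units; within the scatter), the first step at this place on the core of compound 3. Alongside a 1.3-fold higher number from compound 1 to compound 2 (0.13 log units; within the scatter), on the core of compound 1, there are now two steps at this place, and neither separates the groups exchanged, though each step covers only one pair of groups on one core. No measurement at hand bears on why these groups read alike.

For the core, there is a single pair that differs only there: compound 1 at 260 nM and compound 4 at 520 nM. On these data alone, whether the flat reading at this place holds for an amine or a carboxylic acid on the phenyl ring, or for a longer chain on that oxygen, remains open.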